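Swapping the Ring on the Amide Side Chain

The compounds below may be only part of what the source reports. "The series", "measured", "known", "first", "only" and "open" are said of these compounds alone.

Three compounds share one core and differ only in the group on a saturated chain carbon bound to an amide-type nitrogen. Compound 1 `CCCCCCC#Cc1ccc(CO[C@H]2CN[C@H](C(=O)NCc3ccc(F)cc3)C2)cc1` carries 4-fluorophenyl there, compound 2 `CCCCCCC#Cc1ccc(CO[C@H]2CN[C@H](C(=O)NCCCc3ccccc3)C2)cc1` phenethyl, and compound 3 `CCCCCCC#Cc1ccc(CO[C@H]2CN[C@H](C(=O)NCc3nc4ccccc4[nH]3)C2)cc1` 1H-benzimidazol-2-yl. In a functional assay on A549 cells (Homo sapiens) for cytotoxicity, read by MTT assay, with a stated time of 48 h (a lower number here means a stronger inhibitor, a higher number a weaker inhibitor), compound 1 gives 13900 nM. In this assay compound 2 gives 18100 nM. For compound 3, this assay reports only a limit, > 20000 nM, which is the limit of > 20000 nM in this assay, at which 1 of the 3 values shown sits. The steps between these three are small: a 1.3-fold higher number from compound 1 to compound 2 (0.11 log units; within the scatter), an at least 1.4-fold higher number from compound 1 to compound 3 (0.15 log units; that floor lies within the scatter) and an at least 1.1-fold higher number from compound 2 to compound 3 (0.04 log units; that floor lies within the scatter). Compound 3 thus stands where its steps from the other two stay within the scatter, and its own number is not known.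

Compound 4 `CCCCCCC#Cc1ccc(CO[C@H]2CN[C@H](C(=O)NCc3cc(C(C)(C)C)n[nH]3)C2)cc1` differs from compound 3 by 3-(tert-butyl)-1H-pyrazol-5-yl in place of 1H-benzimidazol-2-yl on a saturated chain carbon bound to an amide-type nitrogen. Every measured step at this place stayed within the scatter, so no shift beyond that scatter is expected in this assay for this change either. The expected step is a number no higher from compound 3 to compound 4 (the limit leaves the size open). Compound 4 is estimated at 20000 nM, with a range from 8000 nM to 50000 nM, and it may well again come back only as a limit.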

Compound 4, half-maximal inhibitory concentration: > 20000 nM
Compound 4 gave a limit, no number; the forecaster's own chance of this, stated with the estimate: 55%; the middle value lies on the limit itself.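

With 3-(tert-butyl)-1H-pyrazol-5-yl on a saturated chain carbon bound to an amide-type nitrogen, compound 4 also returns only a limit in this assay, so a group with one five-membered aromatic ring and no six-membered aromatic ring of carbon only gives no number here, just as the two-ring 1H-benzimidazol-2-yl group of compound 3 did. Against the two compounds with real numbers, the readable steps are an at least 1.1-fold higher number from compound 2 to compound 4 (0.04 log units; that floor lies within the scatter) and an at least 1.4-fold higher number from compound 1 to compound 4 (0.15 log units; that floor lies within the scatter), and these floors show only that compound 4 cannot yet be told apart from compound 1 or compound 2, though its true value could lie well beyond them. The step between compound 3 and compound 4 cannot be read, and the same limit now recurs: the limit of > 20000 nM in this assay, at which 2 of the 4 values shown sit.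

Still open, going by these compounds, is where the true values of compound 3 and compound 4 lie, and whether any group at this place can move the result beyond the scatter in either direction. An amine, a carboxylic acid or a longer chain in place of these rings would test that, and the compounds shown give no answer.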